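A few compounds are considered here, and "the series" means these few. Any claim that something is new, unique, unknown or untested is made for them only; others in the source may bear on it.

In a functional assay on A2780 cells (Homo sapiens) for inhibition, read by sulforhodamine B assay (on this read-out higher numbers stand for weaker inhibition of growth and lower numbers for stronger inhibition of growth), compound 1 (`Fc1ccc(-c2ccc(-c3ccc(-c4nc5ccccc5[nH]4)cc3)cc2)cc1`) gives 48200 nM and compound 2 (`FC(F)(F)c1ccc(-c2ccc(-c3ccc(-c4nc5ccccc5[nH]4)cc3)cc2)cc1`) gives 100000 nM while compound 3 (`Oc1cccc2[nH]c(-c3ccc(-c4ccc(-c5ccc(C(F)(F)F)cc5)cc4)cc3)nc12`) gives 6100 nM as the lowest of these three numbers. Compound 4 (`Oc1cccc2[nH]c(-c3ccc(-c4ccc(-c5cccc(Cl)c5)cc4)cc3)nc12`) carries 3-chlorophenyl in place of the 4-(trifluoromethyl)phenyl of compound 3 (3-chlorophenyl in place of 4-(trifluoromethyl)phenyl on an aromatic carbon). The closest measured change of end group is a modest one (a 2.1-fold higher number from compound 1 to compound 2 (0.32 log units; beyond the scatter)). The large step (a 16-fold lower number from compound 2 to compound 3 (1.21 log units; beyond the scatter)) came with the hydroxy that compound 4 keeps, so it says little about this swap. Little change is therefore expected, with no clear step beyond the scatter and a slight drop at most (a 1.4-fold lower number from compound 3 to compound 4 (0.13 log units; within the scatter)). Compound 4 is estimated to give a similar number (4500 nM with an expected range from 1500 nM to 13000 nM).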

Compound 4, concentration for 50% growth inhibition: 2800 nM
The estimate for compound 4 lay 1.6-fold (0.21 log units) above the measured number, within the range that was stated.
By their numbers in this assay, from the lowest: compound 4; then compound 3; then compound 1; then compound 2.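

With the hydroxy kept, the outer ring still affects the result in this assay: 3-chlorophenyl in place of 4-(trifluoromethyl)phenyl gives a 2.2-fold lower number from compound 3 to compound 4 (0.34 log units; beyond the scatter), a modest step. This shows that the end group can still shift growth inhibition once the hydroxy is present. The data shown offer no explanation for this step.

This swap changes both the substituent and where it sits on the ring, so the two contributions remain unseparated. On these data alone, how an amine or a carboxylic acid on that outer ring would behave also remains open.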